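Methoxy to hydroxy on the aryl of compound 3

This account rests on a few compounds, and the source may have more. Where it says the series, first, only, none or still open, it means among the compounds named here.

Four members of the series carry the same core and differ at the two outer aryl groups. Compound 1 `COc1cc(C)cc(-c2c(-c3ccnc(-c4ccc(C(C)=O)cc4)c3)cnn2CC#N)c1` gives in a functional assay on SK-MEL-2 cells (Homo sapiens) for inhibition, read by sulforhodamine B assay, with a stated time of 48 h (a higher number here means that more compound is tolerated, a lower number that less compound is tolerated), only a limit, > 100000 nM. Compound 3 `COc1cc(C)cc(-c2nn(CC#N)cc2-c2ccnc(-c3ccc(N(C)C)cc3)c2)c1` likewise reaches in this assay only the limit > 100000 nM, so no number stands for it. Compound 2 `Cc1cc(O)cc(-c2nn(CC#N)cc2-c2ccnc(-c3ccc(Oc4ccccc4)cc3)c2)c1`, which carries the hydroxy group, gives in this assay a measured value, 44200 nM. Two of the three values shown sit at the limit of > 100000 nM in this assay, at which 2 of the 3 values shown sit, so compound 3 is placed at the tolerant end of what the series shows, without a number of its own. Going by the values given here, no pair of measured compounds differs in a single place, so no measured step exists for the change in question.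

Compound 4 `Cc1cc(O)cc(-c2nn(CC#N)cc2-c2ccnc(-c3ccc(N(C)C)cc3)c2)c1` is the not yet measured partner of compound 3; the change is hydrogen in place of methyl on an oxygen on an aromatic ring. Among the compounds with values here, compound 2, the only hydroxy compound with a number, lies at 44200 nM, but it also carries a different second aryl group, so it gives no direct step. For compound 4 a small shift toward less tolerated compound is expected, an at least 1.2-fold lower number from compound 3 to compound 4 (0.09 log units; that floor lies within the scatter), if any beyond the scatter. Compound 4 is estimated at 80000 nM, within 30000 nM to 200000 nM, with a fair chance that only a limit is again reported.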

Compound 4, concentration lethal to 50% of the cells: > 100000 nM
Compound 4 gave a limit, no number; the forecaster's own chance of this, stated with the estimate: 50%; middle value at least 1.2-fold (0.09 log units) away from the limit.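

In this assay compound 4 gives > 100000 nM, a limit and not a number, so hydroxy in place of methoxy does not by itself bring a measured value, and the step from compound 3, itself a limit, cannot be read. With 3-hydroxy-5-methylphenyl held fixed, the series now has its first readable step, an at least 2.2-fold higher number from compound 2 to compound 4 (0.35 log units; beyond the scatter), for dimethylamino in place of phenoxy on an aromatic carbon, so among these two compounds the measured value of compound 2 goes with the phenoxy group and not with hydroxy alone. The series remains crowded at its tolerant end: the limit of > 100000 nM in this assay, at which 3 of the 4 values shown sit.

Going by these compounds, whether methoxy to hydroxy changes the number at all stays open, as a readable step would need a pair in which both partners leave the limit, for instance a pair carrying phenoxy on both sides. Also open, on these data alone, are how the number moves with other groups in place of phenoxy, such as a carboxylic acid, a primary amine or a longer alkoxy chain, and whether the value of compound 2 depends on its hydroxy group.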